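A few compounds are considered here, and "the series" means these few. Any claim that something is new, unique, unknown or untested is made for them only; others in the source may bear on it.

Compound 1 `COc1ccc(C(=O)O)cc1-c1cccc(COc2ccc3c(c2)CN(C2CCCC2)C3=O)c1`: 100%
Compound 2 `CC(C)CCn1sc2cc(OCc3cccc(-c4ccc(Cl)c(C(=O)O)c4)c3)ccc2c1=O`: 91%

Both values come from an ADME assay on a cell-free system (plasma, Rattus norvegicus) for metabolic stability, read by LC-MS, with a stated time of 1 h, at 37 degrees C, tested at 100 uM; on this read-out higher numbers stand for a more stable compound and lower numbers for a less stable compound. Compound 1 stands level with compound 2 on these numbers: the two values lie within the usual scatter of each other, and no order can be drawn between them.

The next compound to be read is compound 3 `Cc1ccc(C(=O)O)cc1-c1cccc(COc2ccc3c(c2)CN(C2CCCC2)C3=O)c1`, which keeps the rest of compound 1 and carries methyl in place of methoxy on an aromatic carbon, ortho to a large group and para to a carboxy group: methyl in place of methoxy on an aromatic carbon.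

Within the data shown here, the series offers no step between measured compounds that differ in one place, so nothing measured sizes this replacement directly. The expectation rests only on compound 1 at 100% and compound 2 at 91%. In this assay no change beyond the scatter is expected, with a small downward drift as the likelier direction. The expected step is a number 5 percentage points lower from compound 1 to compound 3 (within the scatter). For compound 3 the estimated value is 95%, with an expected range from 84% to 100%.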

Compound 3, percent of the compound remaining: 100%
For compound 3 the middle estimate is 5 percentage points below the measured one, and the stated range covers the measured number.
By their numbers in this assay, from the lowest: compounds 2, 1 and 3 (each within the scatter of the next).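

In this assay, methyl in place of methoxy on an aromatic carbon, ortho to a large group and para to a carboxy group, gives no change at the digits printed from compound 1 to compound 3 (within the scatter). Among these compounds, this is the first step that changes a single place, and it shows that this position can lose the methoxy oxygen, with its hydrogen-bond acceptor, without a shift beyond the usual scatter. No measurement at hand explains this outcome.

Compound 1 and compound 3 share the same reading, and this one step says little about how far the position can be changed. As far as these compounds go, it remains open whether an amine, a hydroxyl group or a longer alkoxy chain on the same carbon would leave the reading in place. From the compounds shown here alone, it is equally open whether the carboxy group contributes to the reading, which a primary amide or a tetrazole in its place would test, since compound 2 differs from compound 1 and compound 3 in more than one place and cannot settle either question.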